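Shifting the Chlorine on the Outer Aryl Ring

The source may hold more compounds than are shown below. What is called first, only, known or untested is meant among the compounds shown, and "the series" means these compounds.

Measured in a functional assay on SGC-7901 cells (Homo sapiens) for antiproliferative activity, read by MTT assay, with a stated time of 24 h; on this read-out higher numbers stand for weaker inhibition and lower numbers for stronger inhibition:
Compound 1 `O=c1[nH]cc(S(=O)(=O)Nc2ccccc2-c2cn(-c3cccc(Cl)c3)nn2)c(=O)[nH]1` gives 2270 nM
Compound 2 `O=c1[nH]cc(S(=O)(=O)Nc2ccccc2-c2cn(-c3ccc(Cl)cc3)nn2)c(=O)[nH]1` gives 2700 nM
Compound 3 `O=c1[nH]cc(S(=O)(=O)Nc2cccc(-c3cn(-c4cccc(Cl)c4)nn3)c2)c(=O)[nH]1` gives 3950 nM

Compound 1 and compound 2 share one core, and the change between them is 4-chlorophenyl in place of 3-chlorophenyl on an aromatic nitrogen. That change produced a 1.2-fold higher number from compound 1 to compound 2 (0.08 log units; within the scatter), so the two numbers cannot be told apart. Compound 3 carries a different core; how its core differs from the core of compound 1 is not broken down here. Its number in this assay lies within the scatter of both compound 1 and compound 2, so no ordering among the three can be claimed.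

The unmeasured compound 4 `O=c1[nH]cc(S(=O)(=O)Nc2cccc(-c3cn(-c4ccc(Cl)cc4)nn3)c2)c(=O)[nH]1` arises from compound 3 by 4-chlorophenyl in place of 3-chlorophenyl on an aromatic nitrogen. The surroundings of the changed group are described identically for both pairs, so this is the same change, not merely the same kind.

Because the earlier step of a 1.2-fold higher number from compound 1 to compound 2 (0.08 log units; within the scatter) stayed within the scatter, the expected step from compound 3 to compound 4 is estimated as a 1.2-fold higher number from compound 3 to compound 4 (0.08 log units; within the scatter). Compound 4 is therefore expected at 4700 nM, with a likely range from 2500 nM to 9000 nM.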

Compound 4, half-maximal inhibitory concentration: 2160 nM
Compound 4: the middle estimate sits 2.2-fold (0.34 log units) above what was measured; measured number below the stated range.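

In this assay, putting 4-chlorophenyl in place of 3-chlorophenyl on the second core gave a 1.8-fold lower number from compound 3 to compound 4 (0.26 log units; within the scatter), so on this core too the two numbers cannot be told apart. Set side by side, the two steps show no real difference between the cores: the same change on two cores in this assay, a 1.2-fold higher number (0.08 log units; within the scatter) from compound 1 to compound 2 and a 1.8-fold lower number (0.26 log units; within the scatter) from compound 3 to compound 4, 2.2-fold (0.34 log units) apart, within the scatter of two such steps. This shows that, on these two cores, the change carries over as a step too small to read; it does not show that the step is truly identical on both, that the opposite directions of the two numbers mean anything, or that the same would hold on a third core.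

The compounds shown leave open whether a group other than chlorine on the outer ring, such as methoxy, trifluoromethyl or an amine, would give a step that rises above the scatter. From the compounds shown here alone, it also remains open whether a bare phenyl ring would give a number that can be told apart from those of the chlorophenyl compounds.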